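Piperazinyl acetamides on a shared core: cytotoxicity notes

This account rests on a few compounds, and the source may have more. Where it says the series, first, only, none or still open, it means among the compounds named here.

Measured compounds:
Compound 1 `Cn1cnnc1SCC(=O)Nc1ccc(-c2nc(-c3ccccc3)c(-c3ccccc3)n2C)cc1` gives 43.1% in a functional assay on HT-29 cells (Homo sapiens) for cytotoxicity, read by MTT assay, with a stated time of 24 h, tested at 6.4 ug/mL; on this read-out higher numbers stand for a stronger effect at the one concentration tested and lower numbers for a weaker effect.
Compound 2 `CN1CCN(CC(=O)Nc2ccc(-c3nc(-c4ccccc4)c(-c4ccccc4)n3C)cc2)CC1` gives 28.8% in this assay.
Compound 3 `CCN1CCN(CC(=O)Nc2ccc(-c3nc(-c4ccccc4)c(-c4ccccc4)n3C)cc2)CC1` gives 17.2% in this assay.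

Compound 3 stands lowest of the three numbers; its nearest neighbour is compound 2, with the step of a number 11.6 percentage points lower from compound 2 to compound 3 (beyond the scatter), and the furthest is compound 1, with the step of a number 25.9 percentage points lower from compound 1 to compound 3 (beyond the scatter). Both steps lie beyond the scatter.

Compound 4 `CN(C)/C=C/N1CCN(CC(=O)Nc2ccc(-c3nc(-c4ccccc4)c(-c4ccccc4)n3C)cc2)CC1` is not yet measured. It differs from compound 3 in one place: 2-(dimethylamino)ethenyl in place of ethyl on an amine nitrogen in a ring.

Of the measured steps, only a number 11.6 percentage points lower from compound 2 to compound 3 (beyond the scatter) touches the same ring nitrogen substituent, and it is modest. The steps of a number 14.3 percentage points lower from compound 1 to compound 2 (beyond the scatter) and a number 25.9 percentage points lower from compound 1 to compound 3 (beyond the scatter) exchange the whole group on the saturated chain carbon bound to the carbonyl carbon and say little about the ring nitrogen substituent itself. Within the data shown here, no measured pair shows a 2-(dimethylamino)ethenyl group, so the direction of the new step cannot be read from the data; the expectation is a step in this assay of about the size seen between compound 2 and compound 3, or none beyond the scatter.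

Compound 4 is therefore estimated at 20%, within 8% to 36%, which is expected to mean the step of a number 2.8 percentage points higher from compound 3 to compound 4 (within the scatter).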

Compound 4, a percentage reported as activity, at one concentration (the size of the read-out at that concentration, not a potency): 12.2%
Compound 4: the middle estimate sits 7.8 percentage points above what was measured; the measured number falls inside the stated range.
By their numbers in this assay, from the lowest: compounds 4 and 3 (each within the scatter of the next); then compound 2; then compound 1.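

Replacing ethyl with 2-(dimethylamino)ethenyl on the amine nitrogen in the ring gives a number 5 percentage points lower from compound 3 to compound 4 (within the scatter) in this assay, so at this position a group with more heavy atoms, a double bond outside aromatic rings and a hydrogen-bond acceptor leaves the read-out at the level seen with ethyl. Measured against methyl, the same group gives a number 16.6 percentage points lower from compound 2 to compound 4 (beyond the scatter), which places methyl above both ethyl and 2-(dimethylamino)ethenyl among the three substituents on this nitrogen, while the exchange of the entire group on the saturated chain carbon bound to the carbonyl carbon gives a number 30.9 percentage points lower from compound 1 to compound 4 (beyond the scatter), the largest step in the set. Nothing available bears on why the read-out follows this course.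

The compounds shown leave open whether a hydrogen on the ring nitrogen, or a 2-(dimethylamino)ethyl chain lacking the double bond, would stand with methyl or with the two larger groups. They also leave open whether this order of substituents on the ring nitrogen holds at concentrations other than the single one tested.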